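Pyrrolidin-1-yl to piperidin-1-yl: compound 3 to compound 4

This account rests on a few compounds, and the source may have more. Where it says the series, first, only, none or still open, it means among the compounds named here.

Compound 3 `CC(CC(C)(C)C)Oc1cccc2ccc(N3CCCC3)nc12` has been measured in a functional assay on IMR-32 cells with melanin-concentrating hormone receptor 1 (Homo sapiens) as the target, read by fluorescence; on this read-out higher numbers stand for weaker inhibition and lower numbers for stronger inhibition. In this assay compound 3 gives > 10000 nM, which is a limit of the assay and not a number. Compound 2 `CC(CC(C)(C)C)Oc1cccc2cccnc12` carries hydrogen where compound 3 carries pyrrolidin-1-yl. In this assay compound 2 gives > 10000 nM, again a limit. The step that the two limits leave unreadable from compound 2 to compound 3 is therefore not readable; the limit of > 10000 nM in this assay, at which 2 of the 3 values shown sit, marks the limit at which both of these values sit. Within the data shown here, compound 1 `CC1CCCCC1Oc1cccc2ccc(N)nc12` differs from compound 3 in two places, and no single step connects it to compound 3. In this assay compound 1 gives 1330 nM.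

Compound 4 `CC(CC(C)(C)C)Oc1cccc2ccc(N3CCCCC3)nc12` differs from compound 3 as follows: piperidin-1-yl in place of pyrrolidin-1-yl on an aromatic carbon. Among the measured compounds shown here, no measured step bears on this exchange, and the one step measured is left unreadable by the two limits. Compound 3 stands at the limit of this assay, so the starting point of the step is itself unknown beyond that limit. Given this, compound 4 is expected to remain at or near the limit as well. The step that the limit leaves unreadable from compound 3 to compound 4 is accordingly expected to be small or not readable. Compound 4 is estimated at 15000 nM, in the range 3000 nM to 60000 nM.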

Compound 4, half-maximal inhibitory concentration: > 10000 nM
Compound 4: a limit, no number; the forecaster's own chance of this, stated with the estimate: 75%; the middle value is on the limit's open side.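

In this assay compound 4 gives > 10000 nM, a limit and not a number. The steps to compound 4 from compound 2 and from compound 3 therefore cannot be read: the limit of > 10000 nM in this assay, at which 3 of the 4 values shown sit.

The compounds shown leave open how far hydrogen, pyrrolidin-1-yl and piperidin-1-yl on this aromatic carbon differ in this assay.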